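Methoxycarbonyl for methoxy: expected step for compound 3

This account rests on a few compounds, and the source may have more. Where it says the series, first, only, none or still open, it means among the compounds named here.

Going by the values given here, compound 2 `COc1ccc(-c2cc(N3CCC(CNS(N)(=O)=O)CC3)ncn2)cc1` gives 35300 nM in a functional assay on MCF7 cells (Homo sapiens) for antiproliferative activity, read by sulforhodamine B assay, with a stated time of 48 h (a higher number here means a weaker inhibitor of growth, a lower number a stronger inhibitor of growth), the highest of the two numbers so far; its nearest neighbour, compound 1 `CCCCc1ccc(-c2cc(N3CCC(CNS(N)(=O)=O)CC3)ncn2)cc1`, gives 21800 nM in this assay. Among the compounds with values here, the only step measured, a 1.6-fold higher number from compound 1 to compound 2 (0.21 log units; within the scatter), lies within the scatter. Compound 3 `COC(=O)c1ccc(-c2cc(N3CCC(CNS(N)(=O)=O)CC3)ncn2)cc1` carries methoxycarbonyl in place of methoxy on an aromatic carbon. Within the data shown here, no measured step touches a methoxycarbonyl group, and the one swap at this position moved nothing beyond the scatter, so for compound 3 the step of a 1.0-fold lower number from compound 2 to compound 3 (0.00 log units; within the scatter) is expected to stay within the scatter. Compound 3 is therefore estimated at 35000 nM in this assay, with a range from 12000 nM to 100000 nM.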

Compound 3, concentration for 50% growth inhibition: 17700 nM
For compound 3 the middle estimate is 2.0-fold (0.30 log units) above the measured one; low and high end bracket the measured number.
By their numbers in this assay, from the lowest: compounds 3, 1 and 2 (each within the scatter of the next).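

In this assay, the place para to a large group now also holds methoxycarbonyl, which brings a double bond outside the aromatic ring, yet a 2.0-fold lower number from compound 2 to compound 3 (0.30 log units; within the scatter) and a 1.2-fold lower number from compound 1 to compound 3 (0.09 log units; within the scatter) both stay within the scatter. Butyl, methoxy and methoxycarbonyl therefore cannot be told apart here, and the position shows no preference among these three groups. No evidence bears on this result.

On these data alone, whether an amine or a carboxylic acid at this place would also stay within the scatter remains open. So does whether any change to the shared core would move the numbers further.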